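Replacing Fluorine by Methyl on the Cyclopropyl Amide

The compounds below may be only part of what the source reports. "The series", "measured", "known", "first", "only" and "open" are said of these compounds alone.

compound 1 `CC(C)C(=O)N1CC2CC(C1)N2`: 19000 nM
compound 2 `O=C([C@H]1C[C@@H]1F)N1CC2CC(C1)N2`: 850 nM
compound 3 `O=C([C@@H]1C[C@H]1F)N1CC2CC(C1)N2`: 120 nM

In an assay on SH-EP1 cells for agonist activity at Neuronal acetylcholine receptor; alpha4/beta2 (Homo sapiens), read by FLIPR and calcium flux (on this read-out lower numbers stand for an effect already at smaller amounts and higher numbers for an effect only at larger amounts of compound), compound 3 stands lowest of the three, with a 7.1-fold lower number from compound 2 to compound 3 (0.85 log units; beyond the scatter) and a 160-fold lower number from compound 1 to compound 3 (2.20 log units; beyond the scatter). Compound 4 `C[C@@H]1C[C@@H]1C(=O)N1CC2CC(C1)N2` differs from it by a group of 4 heavy atoms (4 carbon; one three-membered non-aromatic ring of carbon only) in place of a group of 4 heavy atoms (3 carbon, 1 fluorine; one three-membered non-aromatic ring of carbon only), on a carbonyl carbon. Within the data shown here, the steps that bear on this place are a 22-fold lower number from compound 1 to compound 2 (1.35 log units; beyond the scatter) and a 160-fold lower number from compound 1 to compound 3 (2.20 log units; beyond the scatter), both large, showing that a three-membered ring on the carbonyl carbon matters greatly, and the modest 7.1-fold lower number from compound 2 to compound 3 (0.85 log units; beyond the scatter), where the two compounds differ only in how the ring is drawn (the fact that one of compounds 2 and 3 is drawn with a defined configuration and the other without, at the place where they differ). Swapping fluorine for methyl keeps the ring but not its substituent, so a small rise in the number is expected for compound 4, a 3.3-fold higher number from compound 3 to compound 4 (0.52 log units; beyond the scatter). The expected value for compound 4 is 400 nM, within 100 nM to 2000 nM.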

Compound 4, half-maximal effective concentration: 2100 nM
Compound 4: the middle estimate sits 5.3-fold (0.72 log units) below what was measured; measured number above the stated range.
By their numbers in this assay, from the lowest: compound 3; then compound 2; then compound 4; then compound 1.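

In this assay the three-membered ring alone does not decide the outcome: there is a 9.0-fold lower number from compound 1 to compound 4 (0.96 log units; beyond the scatter) in its favour over isopropyl, but an 18-fold higher number from compound 3 to compound 4 (1.24 log units; beyond the scatter) and a 2.5-fold higher number from compound 2 to compound 4 (0.39 log units; beyond the scatter) show that methyl gives back part of what fluorine gained. The substituent on the ring therefore counts as well as the ring itself. Nothing given here explains the gap between fluorine and methyl. Still open, as far as these compounds go, is how a bare cyclopropyl, or one carrying ethyl or chlorine, would read, and how methyl drawn in another configuration would compare.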